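The compounds below may be only part of what the source reports. "The series", "measured", "known", "first", "only" and "open" are said of these compounds alone.

Among the measured compounds shown here, compound 3, the compound whose structure is `O=C(NO)c1ccc(NCc2nc(-c3ccccc3)nn2-c2ccccc2)cc1`, stands highest of the three numbers so far in an assay on Sf9 cells for inhibition of protein deacetylase HDAC6 (Homo sapiens), read by fluorescence, with a stated time of 40 min, tested at 100 nM (a lower number here means less inhibition, a higher number more inhibition at the concentration tested (going by the name of the read-out)), where compound 3 gives 72.6%. The nearest of the other two is compound 2, whose structure is `O=C(NO)c1ccc(NCc2nc(-c3cccc(Cl)c3)nn2-c2ccccc2)cc1`; in this assay compound 2 gives 61.2%. Furthest is compound 1, with the structure `O=C(NO)c1ccc(NCc2nc(-c3ccc(Br)o3)nn2-c2ccccc2)cc1`, which in this assay gives 55.8%.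

Compound 4, whose structure is `Cc1ccccc1-c1nc(CNc2ccc(C(=O)NO)cc2)n(-c2ccccc2)n1`, is to be measured in this assay. It differs from compound 3 in one place: methyl in place of hydrogen on an aromatic carbon. The change sits on an aromatic carbon of a six-membered aromatic ring of carbon only, ortho to a large group; cut one bond further out it reads phenyl to 2-methylphenyl.

For the measured compounds named here, two measured steps bear on this, both changes on the same ring. The step of a number 11.4 percentage points higher from compound 2 to compound 3 (beyond the scatter) and the step of a number 16.8 percentage points higher from compound 1 to compound 3 (beyond the scatter) both show that the bare phenyl gives the higher number, while any substitution on that ring gave less. Compound 4 adds a group to the bare phenyl, so the expected direction is downward, by a modest amount, as the step of a number 10.6 percentage points lower from compound 3 to compound 4 (beyond the scatter) is estimated. Compound 4 is therefore expected to give 62% in this assay, within a range from 50% to 74%.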

Compound 4, a percentage reported as inhibition, at one concentration (the size of the read-out at that concentration, not a potency): 53.2%
Beside the measured number, compound 4's estimate is 8.8 percentage points above it; low and high end bracket the measured number.
By their numbers in this assay, from the lowest: compounds 4, 1 and 2 (each within the scatter of the next); then compound 3.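

Until now, the lower numbers had come with a chloro on the ring or with 5-bromofuran-2-yl in place of the phenyl. Compound 4 shows that a methyl, with only 1 heavy atom, on an aromatic carbon ortho to a large group also lowers the number in this assay, with a number 19.4 percentage points lower from compound 3 to compound 4 (beyond the scatter). The 2-methylphenyl group does not separate from the other two replacements, with a number 8 percentage points lower from compound 2 to compound 4 (within the scatter) and a number 2.6 percentage points lower from compound 1 to compound 4 (within the scatter), so all three stand together below the bare phenyl of compound 3. Nothing measured here gives a reason for this drop.

The compounds shown leave open whether the loss belongs to this place on the ring or to any methyl on it, since the methyl is seen in one place only. They also leave open how an amine, a carboxylic acid or a methoxy group in the same place would read in this assay, and so whether every added group gives a lower number than the bare phenyl.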